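Replacing fluoro with bromo: what compound 4 should show

A few compounds are considered here, and "the series" means these few. Any claim that something is new, unique, unknown or untested is made for them only; others in the source may bear on it.

In a physicochemical assay for lipophilicity, read by mass spectrometry (a higher number here means a more lipophilic compound, a lower number a more polar compound), compound 1 (`CCc1ccc(NC(=O)C2Cc3cc(OC)c(OC)cc3C2=O)cc1`), which carries ethyl, gives 3.11 on the shared core. Compound 2 (`COc1ccc(NC(=O)C2Cc3cc(OC)c(OC)cc3C2=O)cc1`), with methoxy at that place, gives 2.08 and compound 3 (`COc1cc2c(cc1OC)C(=O)C(C(=O)Nc1ccc(F)cc1)C2`), with fluoro there, gives 2.36 on the same scale. Compound 3 therefore stands level with compound 2 (a number 0.28 log units higher from compound 2 to compound 3 (within the scatter)) and clearly under compound 1 (a number 0.75 log units lower from compound 1 to compound 3 (beyond the scatter)).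

Compound 4 (`COc1cc2c(cc1OC)C(=O)C(C(=O)Nc1ccc(Br)cc1)C2`) has bromo in place of fluoro on an aromatic carbon, para to a large group. Within the data shown here, no bromo compound has been measured, so no step shows this change directly. The closest guide is the modest step between ethyl and fluoro at this place (a number 0.75 log units lower from compound 1 to compound 3 (beyond the scatter)). The large step from ethyl to methoxy (a number 1.03 log units lower from compound 1 to compound 2 (beyond the scatter)) adds little, since methoxy and fluoro do not separate beyond the scatter. Taking the ethyl compound as a rough model for bromo, a modest rise beyond the scatter is expected, estimated as a number 0.59 log units higher from compound 3 to compound 4 (beyond the scatter) in all. In this assay the expected value for compound 4 is 2.95 (estimated range 2.6 to 3.3).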

Compound 4, partition coefficient: 3.03
Compound 4: the middle estimate sits 0.08 log units below what was measured; the measured number falls inside the stated range.
By their numbers in this assay, from the lowest: compounds 2 and 3 (each within the scatter of the next); then compounds 4 and 1 (each within the scatter of the next).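

Exchanging one halogen for another at this place proves enough to move the number in this assay, with a number 0.67 log units higher from compound 3 to compound 4 (beyond the scatter) even though fluoro and bromo each count one heavy atom and no hydrogen-bond donors or acceptors. Ethyl no longer stands alone at the high end of the scale for this place: a number 0.08 log units lower from compound 1 to compound 4 (within the scatter) puts bromo level with ethyl, while a number 0.95 log units higher from compound 2 to compound 4 (beyond the scatter) sets bromo clear of methoxy, so the four groups fall into two levels, ethyl and bromo over fluoro and methoxy. Nothing at hand bears on why the two halogens part in this way, so the gap stands as an observation without an explanation.

The compounds shown leave open where chloro or iodo would fall on this scale, and whether an amine or a carboxylic acid at this place would read beneath the lower level. On these data alone, all four compounds also vary at this one place on the shared core, so how the exchange of fluoro for bromo would read at any other place remains unknown.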